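Compound 3 to compound 4: chloro to hydroxy

The source may report more compounds than this note shows. Statements on the series, on what has been measured and on what is new or still open speak of the compounds shown alone.

In a functional assay on MCF7 cells (Homo sapiens) for inhibition, read by MTT assay, with a stated time of 72 h (on this read-out higher numbers stand for weaker inhibition and lower numbers for stronger inhibition), compound 1 (`COc1cc(OC)c(OC)cc1/C=C/C(=O)c1ccc(Cl)cc1`) gives 29500 nM and compound 2 (`COc1cc(OC)c(OC)cc1/C=C/C(=O)c1ccc(O)cc1O`) gives 33800 nM, with a 1.1-fold higher number from compound 1 to compound 2 (0.06 log units; within the scatter). Compound 3 (`COc1cc(OC)c(OC)cc1/C=C/C(=O)c1cc(Cl)ccc1O`) gives > 150000 nM, which is a limit and not a number. It sits at the limit of > 150000 nM in this assay, at which 1 of the 3 values shown sits.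

Compound 4 (`COc1cc(OC)c(OC)cc1/C=C/C(=O)c1cc(O)ccc1O`) differs from it by hydroxy in place of chloro on an aromatic carbon, giving 2,5-dihydroxyphenyl.

The closest measured steps are an at least 5.0-fold higher number from compound 1 to compound 3 (0.70 log units; beyond the scatter) and an at least 4.4-fold higher number from compound 2 to compound 3 (0.64 log units; beyond the scatter). Since compound 2 also carries two hydroxy groups and gives 33800 nM, a move back toward lower numbers of about that size is expected. A reading for compound 4 that stays as high as that of compound 3 remains possible. The expected change is an at least 3.7-fold lower number from compound 3 to compound 4 (0.57 log units; beyond the scatter). The estimate for compound 4 is 40000 nM, within 12000 nM to 130000 nM.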

Compound 4, half-maximal inhibitory concentration: > 150000 nM
Compound 4 ended at the assay's limit; the forecaster's own chance of this, stated with the estimate: 15%; at least 3.7-fold (0.57 log units) between middle value and limit.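

In this assay compound 4 stands at a limit and not at a number, so replacing chloro with hydroxy at this position brings no measurable return from the limit of compound 3: the limit of > 150000 nM in this assay, at which 2 of the 4 values shown sit. The 2,5-dihydroxyphenyl in place of 2,4-dihydroxyphenyl gives an at least 4.4-fold higher number from compound 2 to compound 4 (0.64 log units; beyond the scatter), so two hydroxy groups alone do not hold the reading down. In place of 4-chlorophenyl, it gives an at least 5.0-fold higher number from compound 1 to compound 4 (0.70 log units; beyond the scatter).

As far as these compounds go, the step between compound 3 and compound 4 cannot be read, so their order stays unknown. From the compounds shown here alone, whether an amine or a carboxylic acid at this position would give a reading under the limit remains open.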